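A few compounds are considered here, and "the series" means these few. Any claim that something is new, unique, unknown or untested is made for them only; others in the source may bear on it.

Measured compounds:
compound 1, `CC(C(=O)NCc1ccc(C(F)(F)F)nc1-c1ccc(N(C)C)cc1)c1ccc(NS(C)(=O)=O)c(F)c1`, 3.2 nM
compound 2, `COc1ccc(-c2nc(C(F)(F)F)ccc2CNC(=O)C(C)c2ccc(NS(C)(=O)=O)c(F)c2)cc1OC`, 25.6 nM

Both compounds were tested in an assay on CHO cells for antagonist activity at transient receptor potential cation channel subfamily V member 1 (Homo sapiens), read by FLIPR; on this read-out lower numbers stand for stronger inhibition and higher numbers for weaker inhibition. Compound 1 gives 3.2 nM, and compound 2 gives 25.6 nM. For the measured compounds named here, compound 2 thus stands at the highest, that is the weaker, of the two numbers, with compound 1 the only neighbour, and the single measured step between them, an 8.0-fold higher number from compound 1 to compound 2 (0.90 log units; beyond the scatter), shows that an exchange of the aryl group at this position moves the number beyond the scatter.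

Compound 3, `CC(C(=O)NCc1ccc(C(F)(F)F)nc1-c1ccc2cc[nH]c2c1)c1ccc(NS(C)(=O)=O)c(F)c1`, has not yet been measured. It differs from compound 2 in one place: 1H-indol-6-yl in place of 3,4-dimethoxyphenyl on an aromatic carbon. Going by the values given here, the only step that bears on this change is an 8.0-fold higher number from compound 1 to compound 2 (0.90 log units; beyond the scatter), since it concerns the same position, but neither measured compound carries a bicyclic group there, so the direction of the new step is not fixed by what is known. On balance compound 3 is expected to give 10 nM in this assay, within 3 nM to 40 nM. That estimate corresponds to an expected step of a 2.6-fold lower number from compound 2 to compound 3 (0.41 log units; beyond the scatter).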

Compound 3, inhibition constant: 20.3 nM
The estimate for compound 3 lay 2.0-fold (0.31 log units) below the measured number, and the stated range covers the measured number.
By their numbers in this assay, from the lowest: compound 1; then compounds 3 and 2 (each within the scatter of the next).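

In this assay, 1H-indol-6-yl in place of 3,4-dimethoxyphenyl gives a 1.3-fold lower number from compound 2 to compound 3 (0.10 log units; within the scatter), so two aryl groups that differ in their rings, and in carrying a hydrogen-bond donor rather than hydrogen-bond acceptors, cannot be told apart at this position next to the ring nitrogen. Against the 4-(dimethylamino)phenyl group, the same 1H-indol-6-yl group gives a 6.3-fold higher number from compound 1 to compound 3 (0.80 log units; beyond the scatter); with the earlier step, this shows that compound 1 stands apart from two structurally different aryl groups rather than from 3,4-dimethoxyphenyl alone, and it has the lowest number of the three. Nothing available explains why these groups compare as they do.

The compounds shown leave open how a plain phenyl or a 4-methoxyphenyl group would compare at this position, and so whether the dimethylamino group itself sets compound 1 apart from the other two. Also open, going by these compounds, is whether the hydrogen on the indole nitrogen matters here, a question that a 1-methyl-1H-indol-6-yl group would address.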